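The compounds below may be only part of what the source reports. "The series", "measured", "known", "first", "only" and "open" are said of these compounds alone.

Measured compounds in an assay on isolated protein for inhibition of Rho-associated protein kinase 1 (Homo sapiens), read by scintillation counting, radiometric assay and 33P incorporation, with a stated time of 40 min, in the presence of a further agent that is not named here; a lower number here means a stronger inhibitor, a higher number a weaker inhibitor:

compound 1, `COc1ccc(OCC(=O)Nc2cccc(NC(=O)c3ccc(N(C)C)cc3)c2)cc1OC`: > 10000 nM, which is a limit of the assay and not a number
compound 2, `O=C(COc1ccc2c(=O)ccoc2c1)Nc1cccc(NC(=O)c2ccccc2)c1`: 120 nM
compound 3, `CCCc1ccc(C(=O)Nc2cccc(NC(=O)COc3ccc4c(=O)ccoc4c3)c2)cc1`: 143 nM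

Compound 1 reaches only the limit of this assay, so nothing more can be said of it. Of the two numbers shown, compound 2 and compound 3 lie within the scatter of each other, as the step of a 1.2-fold higher number from compound 2 to compound 3 (0.08 log units; within the scatter) shows; neither can be called the stronger inhibitor. Compound 4, `CCOc1ccc(C(=O)Nc2cccc(NC(=O)COc3ccc4c(=O)ccoc4c3)c2)cc1`, is not yet measured. It differs from compound 3 in one place: ethoxy in place of propyl on an aromatic carbon. Within the data shown here, the only measured step that touches that aromatic carbon is a 1.2-fold higher number from compound 2 to compound 3 (0.08 log units; within the scatter), which put propyl in place of hydrogen there and stayed within the scatter. On that single piece of evidence, a change of the same size of group at the same place is expected to give a step within the scatter as well, with no clear direction. Compound 4 is therefore expected to give 140 nM in this assay, with a range from 50 nM to 400 nM. The expected step of a 1.0-fold lower number from compound 3 to compound 4 (0.01 log units; within the scatter) is thus estimated to lie within the scatter.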

Compound 4, half-maximal inhibitory concentration: 17 nM
For compound 4 the middle estimate is 8.2-fold (0.92 log units) above the measured one, and the stated range ends above it.
By their numbers in this assay, from the lowest: compound 4; then compounds 2 and 3 (each within the scatter of the next). At a limit, above all of these: compound 1.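

In this assay, swapping propyl for ethoxy, two groups with the same count of heavy atoms, gives an 8.4-fold lower number from compound 3 to compound 4 (0.92 log units; beyond the scatter), so this aromatic carbon, para to a large group, does respond to what sits on it, even though a 1.2-fold higher number from compound 2 to compound 3 (0.08 log units; within the scatter) had suggested little sensitivity. Ethoxy also stands apart from hydrogen at the same place, with a 7.1-fold lower number from compound 2 to compound 4 (0.85 log units; beyond the scatter), so what matters here is which group is added and not simply that one is added. Ethoxy carries an oxygen, a hydrogen-bond acceptor, where propyl has none, yet nothing measured here says why the number falls.

The compounds shown leave open whether methoxy, a longer chain such as propoxy, or an amine at this place would give a similarly low number. They also leave open whether ethoxy would do the same on another carbon of that ring.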